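Butyl-chain variants on the shared core, cytotoxicity in MCF7 cells

A few compounds are considered here, and "the series" means these few. Any claim that something is new, unique, unknown or untested is made for them only; others in the source may bear on it.

Measured so far:
compound 1 `CCCCn1c(Cc2cc(OC)c(OC)c(OC)c2)nc2c(N)nc(F)nc21`: 185000000 nM
compound 2 `CCCCCCn1c(Cc2cc(OC)c(OC)c(OC)c2)nc2c(N)nc(F)nc21`: 112000000 nM
compound 3 `C=CCCCn1c(Cc2cc(OC)c(OC)c(OC)c2)nc2c(N)nc(F)nc21`: 55600000 nM

In a functional assay on MCF7 cells (Homo sapiens) for cytotoxicity (a lower number here means that less compound is needed, a higher number that more compound is needed for the effect), compound 3 gives 55600000 nM, the lowest of the three numbers. One step is a 2.0-fold lower number from compound 2 to compound 3 (0.30 log units; within the scatter), so those two cannot be ranked against each other; another step is a 3.3-fold lower number from compound 1 to compound 3 (0.52 log units; beyond the scatter), a modest but real difference. Between compound 1 and compound 2 the step is a 1.7-fold lower number from compound 1 to compound 2 (0.22 log units; within the scatter).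

Compound 4 `COc1cc(Cc2nc3c(N)nc(F)nc3n2CC2CCCO2)cc(OC)c1OC` is not yet measured. It differs from compound 3 in one place: oxolan-2-yl in place of but-3-en-1-yl on a saturated chain carbon bound to an aromatic nitrogen. The measured steps all vary the same chain on the aromatic nitrogen, but none of them introduces a ring or a hydrogen-bond acceptor there; they show that lengthening the chain or exchanging its end changes this assay by little, with the largest shift being a 3.3-fold lower number from compound 1 to compound 3 (0.52 log units; beyond the scatter). Among the compounds with values here, the double bond that went with the lowest number is lost in compound 4, and the oxolane ring has no precedent. Compound 4 is therefore expected to land near compound 3, with at most a small shift toward a higher number, an estimated step of a 1.4-fold higher number from compound 3 to compound 4 (0.16 log units; within the scatter). The estimate for compound 4 in this assay is 80000000 nM, with a range from 25000000 nM to 250000000 nM.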

Compound 4, half-maximal effective concentration: 147000000 nM
The estimate for compound 4 lay 1.8-fold (0.26 log units) below the measured number; measured number inside the range.
By their numbers in this assay, from the lowest: compounds 3, 2, 4 and 1 (each within the scatter of the next, the first and the last beyond it).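

In this assay, within the data shown here, oxolan-2-yl on a saturated chain carbon bound to an aromatic nitrogen is the first change to bring a ring and a hydrogen-bond acceptor to this place, and replacing but-3-en-1-yl with it gives a modest but real difference (a 2.6-fold higher number from compound 3 to compound 4 (0.42 log units; beyond the scatter)). Replacing the saturated chains with the same group gives differences that cannot be read (a 1.3-fold higher number from compound 2 to compound 4 (0.12 log units; within the scatter); a 1.3-fold lower number from compound 1 to compound 4 (0.10 log units; within the scatter)), so this place tolerates the ring and its oxygen without a separation from compound 1 or compound 2, while compound 3 stands apart from compound 1 and compound 4 but not from compound 2. No evidence is available on what lies behind the difference between but-3-en-1-yl and oxolan-2-yl.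

The compounds shown do not separate the ring from its oxygen: cyclopentyl in place of oxolan-2-yl would test the ring without the oxygen, and an open 2-methoxyethyl chain would test the oxygen without the ring. Also open, as far as these compounds go, is how a charged group at this place, such as an amine or a carboxylic acid, would read in this assay.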